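The source may report more compounds than this note shows. Statements on the series, on what has been measured and on what is new or still open speak of the compounds shown alone.

Measured so far:
Compound 1 `Cc1cc(C(=O)Nc2ccccn2)nn1Cc1cc(Cl)ccc1OCc1ccccc1`: 126 nM
Compound 2 `Cc1cc(C(=O)NCc2ccccn2)nn1Cc1cc(Cl)ccc1OCc1ccccc1`: 25.1 nM

In an assay on CHO-K1 cells for displacement of a labelled ligand from prostaglandin E2 receptor EP1 subtype (Homo sapiens) (on this read-out lower numbers stand for stronger inhibition and higher numbers for weaker inhibition), compound 2 holds the lowest of the two numbers; its nearest neighbour is compound 1, at a 5.0-fold lower number from compound 1 to compound 2 (0.70 log units; beyond the scatter) in the reverse direction. Compound 3 `Cc1cc(NC(=O)CC(C)(C)C)nn1Cc1cc(Cl)ccc1OCc1ccccc1` differs from compound 2 by (neopentylcarbonyl)amino in place of ((pyridin-2-yl)methyl)carbamoyl on an aromatic carbon. Within the data shown here, only the step from compound 1 to compound 2 is known, a 5.0-fold lower number from compound 1 to compound 2 (0.70 log units; beyond the scatter), and it concerns the group on the amide nitrogen alone; the present change is larger and of a different kind, so its size is not read off that step. A higher number than compound 2 is expected for compound 3, a 13-fold higher number from compound 2 to compound 3 (1.11 log units; beyond the scatter), with wide uncertainty. Compound 3 is estimated at 320 nM (range 60 nM to 1700 nM).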

Compound 3, half-maximal inhibitory concentration: 10 nM
Compound 3: middle estimate off by 32-fold (1.51 log units), on the high side; measured number outside the range, below it.
By their numbers in this assay, from the lowest: compound 3; then compound 2; then compound 1.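

In this assay, among these compounds, the ((pyridin-2-yl)methyl)carbamoyl group is not required at this aromatic carbon: (neopentylcarbonyl)amino, which has no ring, gives a 2.5-fold lower number from compound 2 to compound 3 (0.40 log units; beyond the scatter) and is the lowest number so far. Against the (pyridin-2-yl)carbamoyl group, the same replacement gives a 13-fold lower number from compound 1 to compound 3 (1.10 log units; beyond the scatter) in the same direction. No evidence bears on the reason for these steps.

These steps change the direction of the amide and the group it carries together, so the two contributions remain unseparated. Open, going by these compounds, is how a neopentylcarbamoyl or an acetylamino group would read at this carbon.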